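The source may report more compounds than this note shows. Statements on the series, on what has been measured and on what is new or still open speak of the compounds shown alone.

Working notes on the series. Among the measured compounds shown here, compound 2 `O=C(O)c1ccccc1-c1ccc(CCc2ncc(Cc3ccc(Cl)cc3)[nH]2)cc1` gives 102 nM in an in vitro functional assay on cells for agonist activity at Bombesin receptor subtype-3 (Mus musculus), read by luminescence and calcium flux (a lower number here means that less compound is needed, a higher number that more compound is needed for the effect), and stands as the higher of the two numbers measured so far; compound 1 `O=C(O)c1ccccc1-c1ccc(CCc2ncc(CC3CCCC3)[nH]2)cc1` gives 7.9 nM in this assay. For the measured compounds named here, the only measured step, a 13-fold higher number from compound 1 to compound 2 (1.11 log units; beyond the scatter), replaced a saturated ring with an aromatic one at the same place. Compound 3 `N#Cc1cccc(Cc2cnc(CCc3ccc(-c4ccccc4C(=O)O)cc3)[nH]2)c1` differs from compound 2 by 3-cyanophenyl in place of 4-chlorophenyl on a saturated chain carbon bound to an aromatic carbon. Going by the values given here, that change keeps the aromatic ring of compound 2 and alters only what sits on it, a kind of step for which no measured example exists; the step from compound 1 to compound 2 is therefore a poor guide and sets only the scale of what this position can do. With nothing to indicate direction, the expected step is a 1.0-fold lower number from compound 2 to compound 3 (0.01 log units; within the scatter), that is none beyond the scatter. For compound 3 the estimate in this assay is 100 nM, with a range from 25 nM to 400 nM.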

Compound 3, half-maximal effective concentration: 20 nM
For compound 3 the middle estimate is 5.0-fold (0.70 log units) above the measured one, and the stated range ends above it.
By their numbers in this assay, from the lowest: compound 1; then compound 3; then compound 2.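

With a 5.1-fold lower number from compound 2 to compound 3 (0.71 log units; beyond the scatter) in this assay, this position proves sensitive to what the aromatic ring carries, not only to whether the ring is aromatic or saturated. An aromatic ring here is thus not tied to the size of the loss seen with 4-chlorophenyl, although a 2.5-fold higher number from compound 1 to compound 3 (0.40 log units; beyond the scatter) shows that 3-cyanophenyl does not fully match cyclopentyl at this place. Nothing available explains why this change shifts the number.

The nitrile and its place on the ring change together between compound 2 and compound 3, so the shift cannot be assigned to either one alone; 3-chlorophenyl and 4-cyanophenyl on the same saturated chain carbon would separate the two. On these data alone, how a ring carrying an amine would read at this position also remains open.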